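The compounds below may be only part of what the source reports. "The series", "measured", "known", "first", "only" and "open" are said of these compounds alone.

Series notes. Compound 1 `CC(Oc1ncnc2ccc(-c3cnn(C4CCNCC4)c3)cc12)c1c(Cl)ccc(F)c1Cl` and compound 2 `CC(Nc1ncnc2ncc(-c3cnn(C4CCNCC4)c3)cc12)c1c(Cl)ccc(F)c1Cl` carry the same 1-(piperidin-4-yl)-1H-pyrazol-4-yl group on two cores; the difference between the two cores is not broken down here. In a functional assay on A549 cells (Homo sapiens) for antiproliferative activity, read by MTT assay, with a stated time of 72 h (on this read-out lower numbers stand for stronger inhibition and higher numbers for weaker inhibition), compound 1 gives 6750 nM, while compound 2 gives 29700 nM. Compound 3 `CC(Nc1ncnc2ncc(-c3cnn(C)c3)cc12)c1c(Cl)ccc(F)c1Cl` reaches only a limit of this assay, > 100000 nM. The change from compound 2 to compound 3, (methyl in place of piperidin-4-yl on an aromatic nitrogen), produced an at least 3.3-fold higher number from compound 2 to compound 3 (0.52 log units; beyond the scatter); the size of that step is known only as far as the limit of > 100000 nM in this assay, at which 1 of the 3 values shown sits. Compound 4 `CC(Oc1ncnc2ccc(-c3cnn(C)c3)cc12)c1c(Cl)ccc(F)c1Cl` has not yet been measured and arises from compound 1 by the same change, (methyl in place of piperidin-4-yl on an aromatic nitrogen). A step of at least similar size is expected, resting on an at least 3.3-fold higher number from compound 2 to compound 3 (0.52 log units; beyond the scatter). For compound 4 the expected step is therefore a 4.4-fold higher number from compound 1 to compound 4 (0.65 log units; beyond the scatter). Compound 4 is estimated to give 30000 nM in this assay, between 15000 nM and 100000 nM.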

Compound 4, half-maximal inhibitory concentration: 28800 nM
For compound 4 the middle estimate is 1.0-fold (0.02 log units) above the measured one; the measured number falls inside the stated range.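

In this assay, methyl in place of piperidin-4-yl on an aromatic nitrogen gives a 4.3-fold higher number from compound 1 to compound 4 (0.63 log units; beyond the scatter), so the change raises the number on both cores shown. The two steps compare as follows: the same change on two cores in this assay, an at least 3.3-fold higher number (0.52 log units; beyond the scatter) from compound 2 to compound 3 and a 4.3-fold higher number (0.63 log units; beyond the scatter) from compound 1 to compound 4; the limit leaves it open whether they differ. Compound 3 gives > 100000 nM, which is a limit of the assay, so a step of equal size on the two cores is not shown.

The compounds shown leave open whether the lower numbers with piperidin-4-yl depend on its ring nitrogen or on the ring itself; cyclohexyl or a simple aminoethyl chain on the same aromatic nitrogen would separate the two. On these data alone, whether the step carries over to any further core also remains open.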